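Butyl to silicon group on the triazole of compound 2

The source may report more compounds than this note shows. Statements on the series, on what has been measured and on what is new or still open speak of the compounds shown alone.

Three compounds of the shared core have numbers in a functional assay on A549 cells (Homo sapiens) for antiproliferative activity, read by MTT assay, with a stated time of 72 h; on this read-out lower numbers stand for stronger inhibition and higher numbers for weaker inhibition. Compound 1 `O=C1O[C@H]([C@@H](O)Cn2cc(-c3cc(C(F)(F)F)cc(C(F)(F)F)c3)nn2)C(OCc2ccccc2)=C1OCc1ccccc1` gives 28900 nM. Compound 2 `CCCCc1cn(C[C@H](O)[C@H]2OC(=O)C(OCc3ccccc3)=C2OCc2ccccc2)nn1` gives 28600 nM; compound 2 thus holds the lowest of the two numbers, its nearest neighbour being compound 1 at a gap that stays within the usual scatter, so no order between the two can be read. Compound 3 `O=C1O/C(=C\Cn2cc(-c3cc(C(F)(F)F)cc(C(F)(F)F)c3)nn2)C(OCc2ccccc2)=C1OCc1ccccc1`, whose core differs, reaches only the limit of this assay, > 100000 nM, and no number is reported for it (the limit of > 100000 nM in this assay, at which 1 of the 3 values shown sits).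

The step of interest is from compound 2 to compound 4 `C[Si](C)(C)c1cn(C[C@H](O)[C@H]2OC(=O)C(OCc3ccccc3)=C2OCc2ccccc2)nn1`, not yet measured in this assay. The change is a group of 4 heavy atoms (3 carbon, 1 silicon; no ring) in place of a group of 4 heavy atoms (4 carbon; no ring), on an aromatic carbon. The departing butyl and the entering group match in heavy-atom count, carry no ring, no donor and no acceptor, and sit on the same aromatic carbon of the five-membered ring with three nitrogens.

For the measured compounds named here, no measured step between compounds differing in one place exists in this set, so the expectation rests on the like-for-like swap alone: a step of no more than the scatter, in either direction. Compound 4 is therefore expected to give about 26000 nM, within 10000 nM to 70000 nM, the estimated step being a 1.1-fold lower number from compound 2 to compound 4 (0.04 log units; within the scatter).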

Compound 4, half-maximal inhibitory concentration: 19200 nM
For compound 4 the middle estimate is 1.4-fold (0.13 log units) above the measured one; the measured number falls inside the stated range.
By their numbers in this assay, from the lowest: compounds 4, 2 and 1 (each within the scatter of the next). At a limit, above all of these: compound 3.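

In this assay, the swap of butyl for trimethylsilyl on the aromatic carbon of the five-membered ring gives a 1.5-fold lower number from compound 2 to compound 4 (0.17 log units; within the scatter), so silicon in place of carbon at this spot leaves no readable change in the number. Compound 1, with a bis(trifluoromethyl)phenyl group on the same carbon, gives 28900 nM, and compound 4 gives 19200 nM; no order can be read between them, so an aromatic ring and a small silicon group on this carbon are not told apart on this read-out. Nothing measured here gives a cause for the step.

On these data alone, whether any group on this carbon can move the number beyond the scatter stays open, for instance an amine, a carboxylic acid or a longer alkyl chain. As far as these compounds go, the value of compound 3, > 100000 nM, is a limit, and how trimethylsilyl in place of its aryl group would read on that core also stays open.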